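The source may report more compounds than this note shows. Statements on the series, on what has been measured and on what is new or still open speak of the compounds shown alone.

Of the compounds shown here, three stand measured so far: compound 1 `Cn1c(-c2cccnc2)nc2ccc(-c3ccccc3Cl)c(CN)c21`, compound 2 `Cn1cnc2ccc(-c3ccccc3CO)c(CN)c21` and compound 3 `Cn1cnc2cc(Br)c(-c3ccccc3Cl)c(CN)c21`. In an in vitro ADME assay on microsomes from liver (Homo sapiens) for metabolic stability (on this read-out lower numbers stand for a shorter-lived compound and higher numbers for a longer-lived compound), compound 1 gives 1.6 h, compound 2 gives 1.67 h and compound 3 gives 2.93 h. Compound 1 holds the lowest of the three numbers, yet its gap to compound 2 and its gap to compound 3 both stay within the usual scatter, so the three values are not told apart. Compound 4 `Cc1nc2ccc(-c3ccccc3Cl)c(CN)c2n1C` is not yet measured. It differs from compound 1 by methyl in place of pyridin-3-yl on an aromatic carbon. Within the data shown here, no measured pair of the series carries this change, and the measured values themselves do not separate. For compound 4 the step in this assay is expected to stay within the scatter, without a claimed direction, as a 1.1-fold higher number from compound 1 to compound 4 (0.05 log units; within the scatter). Compound 4 is expected to give 1.8 h, between 0.9 h and 3.6 h.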

Compound 4, half-life: > 3.33 h
Compound 4: no number, only a limit; the forecaster's own chance of this, stated with the estimate: 5%; at least 1.8-fold (0.26 log units) between middle value and limit.
By their numbers in this assay, from the lowest: compounds 1, 2 and 3 (each within the scatter of the next). At a limit, above all of these: compound 4.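

In this assay, among these compounds, the aromatic carbon between two ring nitrogen atoms now shows a readable response, which the earlier compounds, all within the scatter of one another, could not show: methyl in place of pyridin-3-yl gives an at least 2.0-fold higher number from compound 1 to compound 4 (0.31 log units; beyond the scatter). Losing the six-membered aromatic ring at this place therefore does not cost half-life in this pair. The step has only a lower bound, as compound 4 carries a limit and not a number: the limit of > 3.33 h in this assay, at which 1 of the 4 values shown sits.

Still open, from the compounds shown here alone, is the true size of the step. Also open, going by these compounds, is how an ethyl chain or an amine on this carbon would read.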